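The compounds below may be only part of what the source reports. "The series", "measured", "known", "first", "only" and "open" are said of these compounds alone.

Compound 1 `COc1cc(NC(=O)Nc2cc(Nc3ccc(C)c(F)c3)ncn2)cc(OC)c1` gives 39.7% in a functional assay on NCI-H226 cells (Homo sapiens) for inhibition, read by MTT assay, with a stated time of 48 h, tested at 10 uM; on this read-out lower numbers stand for less inhibition and higher numbers for more inhibition at the one concentration tested (going by the name of the read-out).
Compound 2 `O=C(Nc1cc(Nc2ccc(F)c(Cl)c2)ncn1)Nc1c(Cl)cccc1Cl` gives 47.3% in this assay.
Compound 3 `COc1cc(Nc2cc(NC(=O)Nc3c(Cl)cccc3Cl)ncn2)cc(C(F)(F)F)c1` gives 33.1% in this assay.

These three numbers all fall within the usual scatter of one another, so compound 1 cannot be set above or below compound 2 or compound 3 on this evidence; the three values simply look alike. Each of the three shares the same core, a urea joined to an aromatic ring that carries a further amino-linked aromatic ring, and they differ in the groups on either end of that core.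

Compound 4 `COc1cc(NC(=O)Nc2cc(Nc3cc(Br)ccc3OC)ncn2)cc(OC)c1` has not yet been measured in this assay. It differs from compound 1 in one place: 5-bromo-2-methoxyphenyl in place of 3-fluoro-4-methylphenyl on a nitrogen on an aromatic ring. Among the compounds with values here, no step between measured compounds shows what such an exchange does to the read-out, and nothing among the three measured compounds points in either direction. The step from compound 1 to compound 4 is therefore expected to be a number 1.7 percentage points lower from compound 1 to compound 4 (within the scatter), nothing beyond the scatter. Compound 4 is estimated at 38%, with a range from 22% to 55%.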

Compound 4, a percentage reported as inhibition, at one concentration (the size of the read-out at that concentration, not a potency): 42.7%
For compound 4 the middle estimate is 4.7 percentage points below the measured one, within the range that was stated.
By their numbers in this assay, from the lowest: compounds 3, 1, 4 and 2 (each within the scatter of the next, the first and the last beyond it).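

In this assay, this position now has its first direct reading: a number 3 percentage points higher from compound 1 to compound 4 (within the scatter) comes with 5-bromo-2-methoxyphenyl in place of 3-fluoro-4-methylphenyl on a nitrogen on an aromatic ring. Although the entering group differs in its atoms and brings a hydrogen-bond acceptor that the leaving group lacks, the read-out does not tell these two compounds apart, so this particular exchange leaves no mark beyond the usual scatter. No measurement at hand offers an explanation for this result.

Because bromine and methoxy enter together, and fluorine and methyl leave together, this single step cannot assign any share of the outcome to one substituent alone. From the compounds shown here alone, it also remains open whether a quite different group on this ring, such as an amine, a carboxylic acid or a longer chain, would shift the number beyond the scatter.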